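Selenoether chain amides: hydroxy added to the saturated chain

The source may report more compounds than this note shows. Statements on the series, on what has been measured and on what is new or still open speak of the compounds shown alone.

Series of selenoether chain amides tested in an assay on HEK293 cells for antagonist activity at transient receptor potential cation channel subfamily V member 2 (Rattus norvegicus), read by fluorescence and calcium flux, with a stated time of 5 min; on this read-out higher numbers stand for weaker inhibition and lower numbers for stronger inhibition. Compound 1 `CCCCC/C=C\C/C=C\CCCCCCCC[Se]CCC(=O)NCc1ccc(O)c(OC)c1` gives 2300 nM in this assay. Among the measured compounds shown here, compound 2 `CCCCCCCC/C=C\CCCCCCCC[Se]CCC(=O)NCc1ccc(O)c(OC)c1` gives 3200 nM in this assay, the highest of the two numbers so far, with compound 1 nearest; the only measured step, a 1.4-fold higher number from compound 1 to compound 2 (0.14 log units; within the scatter), lies within the scatter. Compound 3 `CCCCCC[C@@H](O)C/C=C\CCCCCCCC[Se]CCC(=O)NCc1ccc(O)c(OC)c1` carries hydroxy in place of hydrogen on a saturated chain carbon bound to two saturated chain carbons; cut one bond further out, the difference reads heptyl to 1-hydroxyheptyl. For the measured compounds named here, the one measured step concerns the saturated against the unsaturated end of the chain and not an added hydroxy group, so it bears only loosely on this change; no measured pair shows what a hydroxy group on this chain does. The step from compound 2 to compound 3 is therefore expected to be a 1.1-fold lower number from compound 2 to compound 3 (0.03 log units; within the scatter) in this assay, that is nothing beyond the scatter, with wide uncertainty. Compound 3 is estimated at 3000 nM in this assay, expected within 900 nM to 10000 nM.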

Compound 3, half-maximal inhibitory concentration: 1400 nM
Compound 3: the middle estimate sits 2.1-fold (0.33 log units) above what was measured; the range from low to high includes it.
By their numbers in this assay, from the lowest: compounds 3, 1 and 2 (each within the scatter of the next, the first and the last beyond it).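

In this assay, among the compounds shown here, hydroxy in place of hydrogen on a saturated chain carbon bound to two saturated chain carbons gives a 2.3-fold lower number from compound 2 to compound 3 (0.36 log units; beyond the scatter) and is the first modest step beyond the scatter, so this part of the chain does respond to a change. Taking 1-hydroxyheptyl in place of hept-1-en-1-yl gives a 1.6-fold lower number from compound 1 to compound 3 (0.22 log units; within the scatter) and remains within the scatter, so compound 3 cannot be separated from compound 1 on this read-out. No measurement at hand explains the response to hydroxy.

Going by these compounds, whether an amine, a methoxy group or a ketone on the same carbon would give a similar step remains open, as does the effect of the opposite configuration at that carbon. Also open, on these data alone, is whether the step would hold with a sulfur atom in place of selenium in the chain.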